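Diaryl urea series: chloro to fluoro on the aryl ring

This account rests on a few compounds, and the source may have more. Where it says the series, first, only, none or still open, it means among the compounds named here.

Measured in a functional assay on MGC-803 cells (Homo sapiens) for antiproliferative activity, read by MTT assay, with a stated time of 48 h; on this read-out higher numbers stand for weaker inhibition and lower numbers for stronger inhibition:
compound 1 `O=C(Nc1cccc(CNc2nccnc2Cl)c1)Nc1ccccc1Cl` gives 7130 nM
compound 2 `O=C(Nc1cccc(CNc2nccnc2Cl)c1)Nc1ccc(Cl)cc1Br` gives 7480 nM
compound 3 `O=C(Nc1cccc(CNc2nccnc2Cl)c1)Nc1ccc(Cl)c(Cl)c1` gives 4970 nM

Compound 3 carries the lowest number of the three, yet its steps to the others, a 1.4-fold lower number from compound 1 to compound 3 (0.16 log units; within the scatter) and a 1.5-fold lower number from compound 2 to compound 3 (0.18 log units; within the scatter), stay within the scatter, as does a 1.0-fold higher number from compound 1 to compound 2 (0.02 log units; within the scatter); the three aryl variants so far read as one level. Compound 4 `O=C(Nc1cccc(CNc2nccnc2Cl)c1)Nc1ccc(F)c(Cl)c1` differs from compound 3 only by fluoro in place of chloro on an aromatic carbon. Going by the values given here, no measured step swaps a single halogen at this position alone, so the bearing steps are indirect, and all of them are small. A change of no more than the scatter is expected in this assay, with the step from compound 3 to compound 4 estimated as a 1.1-fold higher number from compound 3 to compound 4 (0.04 log units; within the scatter). Compound 4 is expected at 5500 nM, in the range 2500 nM to 12000 nM.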

Compound 4, half-maximal inhibitory concentration: 5020 nM
Beside the measured number, compound 4's estimate is 1.1-fold (0.04 log units) above it; measured number inside the range.
By their numbers in this assay, from the lowest: compounds 3, 4, 1 and 2 (each within the scatter of the next).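

In this assay, fluoro in place of chloro at this position gives a 1.0-fold higher number from compound 3 to compound 4 (0.00 log units; within the scatter), so the swap between these two halogens, para to the large group, leaves the reading unmoved. The other steps, a 1.5-fold lower number from compound 2 to compound 4 (0.17 log units; within the scatter) and a 1.4-fold lower number from compound 1 to compound 4 (0.15 log units; within the scatter), place compound 4 on the same level as the earlier aryl variants. Nothing at hand offers an explanation for this level reading. Open, going by these compounds, is whether a non-halogen group at this position, such as methoxy or an amine, would leave that level. Also open, on these data alone, is whether any aryl change gives a step beyond the scatter.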